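Reversed enone on the pyrazolopyrimidine chalcone series

The source may report more compounds than this note shows. Statements on the series, on what has been measured and on what is new or still open speak of the compounds shown alone.

Compound 1 `COc1ccc(-c2cc(C(=O)/C=C/c3ccc(C)cc3)nc3cc(-c4ccccc4)nn23)cc1OC` is measured in a functional assay on MDA-MB-231 cells (Homo sapiens) for antiproliferative activity, read by MTT assay, with a stated time of 24 h (on this read-out higher numbers stand for weaker inhibition and lower numbers for stronger inhibition), at 22600 nM. Among the compounds with values here, the only other measured compound, compound 2 `COc1ccc(/C=C/C(=O)c2cc(-c3cc(OC)c(OC)c(OC)c3)n3nc(-c4ccccc4)cc3n2)cc1`, gives in this assay 16500 nM. Within the data shown here, the two numbers differ by less than the usual scatter, so compound 1 cannot be separated from compound 2 on these data; both sit at weak inhibition, and no step between measured compounds that differ in a single place is available.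

Compound 3 `COc1ccc(-c2cc(/C=C/C(=O)c3ccccc3)nc3cc(-c4ccccc4)nn23)cc1OC` has not yet been measured in this assay. Its structural change from compound 1 is 2-benzoylethenyl in place of (2-(4-methylphenyl)ethenyl)carbonyl on an aromatic carbon. The enone is thus turned around and the methyl on the distal ring is dropped, while the shared core and the 3,4-dimethoxyphenyl group are kept.

Among the measured compounds shown here, with no single-point step in hand, the expectation rests only on compound 1 at 22600 nM and compound 2 at 16500 nM, both weak. Compound 3 is estimated at 20000 nM, with a range from 7000 nM to 60000 nM. The step from compound 1 to compound 3 is expected to be a 1.1-fold lower number from compound 1 to compound 3 (0.05 log units; within the scatter), that is, nothing beyond the scatter in either direction.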

Compound 3, half-maximal inhibitory concentration: 11800 nM
Estimate against measurement, compound 3: 1.7-fold (0.23 log units) above; low and high end bracket the measured number.
By their numbers in this assay, from the lowest: compounds 3, 2 and 1 (each within the scatter of the next).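

In this assay, within the data shown here, 2-benzoylethenyl in place of (2-(4-methylphenyl)ethenyl)carbonyl on this aromatic carbon gives a 1.9-fold lower number from compound 1 to compound 3 (0.28 log units; within the scatter), the only single-place comparison available so far. At this position, then, turning the enone around and dropping the methyl from the distal ring, taken together, leave the number within the scatter, and the series stays at weak inhibition with either enone direction. No measured data bear on what lies behind this result.

The compounds shown leave open how much of the step belongs to the direction of the enone and how much to the methyl, since the two change together in this one exchange. Also open, on these data alone, is whether a different kind of group on this aromatic carbon, such as an amine, a carboxylic acid or a longer saturated chain in place of the whole enone, would shift the number beyond the scatter in this assay.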